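Swapping the chlorophenyl of compound 3 for a thiophene

The source may report more compounds than this note shows. Statements on the series, on what has been measured and on what is new or still open speak of the compounds shown alone.

Measured compounds so far:
compound 1, `O/N=C(/Nc1ccccc1)c1ccc2occc2c1`: 19000 nM
compound 2, `O/N=C(/NCc1ccccc1)c1ccc2occc2c1`: 28200 nM
compound 3, `O/N=C(/NCc1cccc(Cl)c1)c1ccc2occc2c1`: 5800 nM

These three share one core and differ only in the group attached to the amine nitrogen. In an assay on tissue (HeLa cells) for inhibition of Indoleamine 2,3-dioxygenase 1 (Homo sapiens), read by spectrophotometry (a lower number here means a stronger inhibitor, a higher number a weaker inhibitor), compound 3 gives the lowest number of the three, with compound 1 nearest and compound 2 furthest away, both beyond the scatter. Within the data shown here, the single one-place step among them is a 4.9-fold lower number from compound 2 to compound 3 (0.69 log units; beyond the scatter), so the chloro atom on the ring accounts for most of what separates compound 3 from compound 2.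

Compound 4, `O/N=C(/NCc1cccs1)c1ccc2occc2c1`, has not been measured. It differs from compound 3 in one place: thiophen-2-yl in place of 3-chlorophenyl on a saturated chain carbon bound to an amine nitrogen. This change removes the chloro whose addition gave the step from compound 2 to compound 3, and at the same time replaces the six-membered ring with a smaller five-membered one containing sulfur. Among the measured compounds shown here, no measured pair shows what a thiophene does here, so the only guidance is that the gain tied to the chloro is lost. A weaker result than compound 3 is therefore expected, roughly back toward compound 2, the step being estimated as a 2.6-fold higher number from compound 3 to compound 4 (0.41 log units; beyond the scatter). For compound 4 the expected value is 15000 nM, within a range from 5000 nM to 45000 nM.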

Compound 4, half-maximal inhibitory concentration: 16200 nM
For compound 4 the middle estimate is 1.1-fold (0.03 log units) below the measured one; the measured number falls inside the stated range.
By their numbers in this assay, from the lowest: compound 3; then compounds 4, 1 and 2 (each within the scatter of the next).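

In this assay, the change gives a 2.8-fold higher number from compound 3 to compound 4 (0.45 log units; beyond the scatter), so at this place on the saturated chain carbon, thiophen-2-yl does not keep the level reached with 3-chlorophenyl. Thiophen-2-yl in place of unsubstituted phenyl gives a 1.7-fold lower number from compound 2 to compound 4 (0.24 log units; within the scatter), and (thiophen-2-yl)methyl in place of phenyl on the amine nitrogen gives a 1.2-fold lower number from compound 1 to compound 4 (0.07 log units; within the scatter); both steps lie within the scatter, so among these four compounds only compound 3 stands clearly apart. Nothing measured here explains these results.

The compounds shown leave open whether a chloro atom on the thiophene ring would lower the number as it does on the phenyl ring. They also leave open how a pyridine ring or a longer chain on the amine nitrogen would read.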